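Swapping phenoxy for (pyridin-3-yl)amino

This account rests on a few compounds, and the source may have more. Where it says the series, first, only, none or still open, it means among the compounds named here.

Compound 1 `CC(O)(c1ccc(-c2ccc(S(=O)(=O)c3ccc(N)nc3)nc2NCc2ccccc2)nc1)C(F)(F)F`: 114 mL.min-1.g-1
Compound 2 `CC(O)(c1ccc(-c2ccc(S(=O)(=O)c3ccc(N)nc3)nc2Oc2ccccc2)nc1)C(F)(F)F`: 213 mL.min-1.g-1

For the measured compounds named here, both values come from an ADME assay (liver) for metabolic stability, with Liver microsome (Rattus norvegicus) as the target, using microsomes and NADPH, with a stated time of 30 min, at 37 degrees C, tested at 1 uM (a lower number here means slower removal, a higher number faster removal of the compound), and with only two compounds measured, compound 2 stands level with compound 1, since their values lie within the scatter of each other. Compound 3 `CC(O)(c1ccc(-c2ccc(S(=O)(=O)c3ccc(N)nc3)nc2Nc2cccnc2)nc1)C(F)(F)F` has not yet been measured. It carries (pyridin-3-yl)amino in place of phenoxy on an aromatic carbon, next to the ring nitrogen: (pyridin-3-yl)amino in place of phenoxy on an aromatic carbon. Going by the values given here, only one measured step bears on this change, because it alters the same place: a 1.9-fold higher number from compound 1 to compound 2 (0.27 log units; within the scatter), with phenoxy in place of benzylamino. That step stays within the scatter, so no step beyond the scatter is expected in this assay, and any direction is tentative. The estimated step is a 1.5-fold lower number from compound 2 to compound 3 (0.18 log units; within the scatter). Compound 3 is expected at about 140 mL.min-1.g-1, with an estimated range of 60 mL.min-1.g-1 to 300 mL.min-1.g-1.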

Compound 3, intrinsic clearance in microsomes: 142 mL.min-1.g-1
Compound 3: middle estimate off by 1.0-fold (0.01 log units), on the low side; the range from low to high includes it.
By their numbers in this assay, from the lowest: compounds 1, 3 and 2 (each within the scatter of the next).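

With the third group in place, this position has now carried three different aromatic side groups in this assay. Exchanging phenoxy for (pyridin-3-yl)amino changes the linking atom, adds a ring nitrogen and brings in a hydrogen-bond donor, yet the result stays within the scatter (a 1.5-fold lower number from compound 2 to compound 3 (0.18 log units; within the scatter)), and so does pyridin-3-yl in place of benzyl on the nitrogen (a 1.2-fold higher number from compound 1 to compound 3 (0.10 log units; within the scatter)), so compounds 1, 2 and 3 stand level with one another. No measurement here gives a reason for these numbers.

A phenylamino group would be needed to separate the effect of the linking nitrogen from that of the ring nitrogen. As far as these compounds go, whether a group without an aromatic ring at this place, such as morpholine or a short alkylamine, would move the number beyond the scatter remains open.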